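Notes on the aryl change from compound 2 to compound 4

This account rests on a few compounds, and the source may have more. Where it says the series, first, only, none or still open, it means among the compounds named here.

Compound 2 `O=C(CSc1nnnn1-c1cccc2ccccc12)N/N=C/c1ccc([N+](=O)[O-])cc1` gives in an ADME assay on MT4 cells (Homo sapiens) for cytotoxicity, read by MTT assay (on this read-out higher numbers stand for lower toxicity in this test and lower numbers for higher toxicity in this test), only a limit, >= 260000 nM. Compound 1 `O=C(CSc1nnnn1-c1cccc2ccccc12)N/N=C/c1ccccc1F` likewise reaches only a limit in this assay, >= 118000 nM. Compound 3 `COc1ccc(/C=N/NC(=O)CSc2nnnn2-c2cccc3ccccc23)c(OC)c1` gives a number in this assay, 28300 nM. Compound 4 `CN(C)c1ccc(/C=N/NC(=O)CSc2nnnn2-c2cccc3ccccc23)cc1` differs from compound 2 by dimethylamino in place of nitro on an aromatic carbon. For the measured compounds named here, two measured steps touch the same aryl group: an at least 9.1-fold lower number from compound 2 to compound 3 (0.96 log units; beyond the scatter) and an at least 4.1-fold lower number from compound 1 to compound 3 (0.62 log units; beyond the scatter); both move from a limit to a number once the aryl group is exchanged. A further exchange of the aryl group from compound 2 may therefore also bring a lower number, though its size cannot be read from a limit. For compound 4 the expected step is an at least 2.3-fold lower number from compound 2 to compound 4 (0.37 log units; beyond the scatter). Compound 4 is estimated at 110000 nM, between 30000 nM and 300000 nM.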

Compound 4, half-maximal cytotoxic concentration: > 289000 nM
Compound 4: a limit, no number (the forecaster's own chance of this, stated with the estimate: 40%); middle value at least 2.6-fold (0.41 log units) away from the limit.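

Compound 4 gives only a limit in this assay, > 289000 nM. For the compounds shown here, the 4-(dimethylamino)phenyl group thus shows that replacing nitro with dimethylamino on this aromatic carbon does not bring the lower number seen with the 2,4-dimethoxyphenyl group, and the one readable step is an at least 10-fold higher number from compound 3 to compound 4 (1.00 log units; beyond the scatter). The steps from compound 1 and compound 2 to compound 4 cannot be read, with limits on both sides.

From the compounds shown here alone, whether a 4-methoxyphenyl or 2-methoxyphenyl group alone would give a number like that of compound 3 stays open. Going by these compounds, the order among compound 1, compound 2 and compound 4 also stays open.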